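The source may report more compounds than this note shows. Statements on the series, on what has been measured and on what is new or still open speak of the compounds shown alone.

Measured so far: compound 1 `O=C(COc1ccc(CNC2CC=C(c3c[nH]c4cccc(F)c34)CC2)c(F)c1)NO` gives 189 nM in a functional assay on SW480 cells (Homo sapiens) for antiproliferative activity, with a stated time of 72 h; on this read-out lower numbers stand for stronger inhibition and higher numbers for weaker inhibition; compound 2 `Cc1ccc2[nH]cc(C3=CCN(Cc4ccc(OCC(=O)NO)cc4F)CC3)c2c1` gives 1950 nM; compound 3 `O=C(COc1ccc(CNC2CC=C(c3c[nH]c4ccccc34)CC2)c(F)c1)NO` gives 1150 nM.

Compound 1 and compound 3 share a core; the step hydrogen in place of fluoro on an aromatic carbon gives a 6.1-fold higher number from compound 1 to compound 3 (0.78 log units; beyond the scatter). The difference between the core of compound 1 and the core of compound 2 is not broken down here. Compound 4 `Cc1ccc2[nH]cc(C3=CCN(Cc4ccc(OCC(=O)NO)cc4)CC3)c2c1` has not yet been measured; it differs from compound 2 by hydrogen in place of fluoro on an aromatic carbon. This is the same kind of change as that from compound 1 to compound 3, but not the same: there the place was part of a fused or bridged system of two rings, ortho and meta to a fused ring, whereas here it is ortho to a large group and meta to a (hydroxycarbamoyl)methoxy group. Because the earlier step of a 6.1-fold higher number from compound 1 to compound 3 (0.78 log units; beyond the scatter) sits at a different place, a smaller step is expected from compound 2 to compound 4, about a 1.4-fold higher number from compound 2 to compound 4 (0.16 log units; within the scatter). Compound 4 is therefore estimated at 2800 nM, expected between 1100 nM and 7000 nM.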

Compound 4, half-maximal inhibitory concentration: 3960 nM
For compound 4 the middle estimate is 1.4-fold (0.15 log units) below the measured one, within the range that was stated.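

In this assay, hydrogen in place of fluoro gives a 2.0-fold higher number from compound 2 to compound 4 (0.31 log units; beyond the scatter), so this change weakens inhibition on both cores. The direction carries over from one core to the other, but the size does not: the same change on two cores in this assay, a 6.1-fold higher number (0.78 log units; beyond the scatter) from compound 1 to compound 3 and a 2.0-fold higher number (0.31 log units; beyond the scatter) from compound 2 to compound 4, 3.0-fold (0.48 log units) apart, beyond the scatter of two such steps The two fluoro groups also sit at different places, and these four compounds cannot separate an effect of the core from an effect of the place.

On these data alone, it remains open whether chloro or methoxy at these same places would behave like fluoro. As far as these compounds go, it is also open what size of step fluoro would give if it stood at the same place on both cores.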